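The source may hold more compounds than are shown below. What is called first, only, known or untested is meant among the compounds shown, and "the series" means these compounds.

Compound 2 `CC(C)(C)c1cn(C[C@H](O)[C@H]2OC(=O)C(OCc3ccccc3)=C2OCc2ccccc2)nn1` gives 730 nM in a functional assay on MCF7 cells (Homo sapiens) for antiproliferative activity, read by MTT assay, with a stated time of 72 h (a higher number here means a weaker inhibitor, a lower number a stronger inhibitor), the lowest of the two numbers shown, while compound 3 `O=C1O/C(=C\Cn2cc(-c3cccc(O)c3)nn2)C(OCc2ccccc2)=C1OCc1ccccc1` gives 27800 nM. Compound 1 `O=C1O/C(=C\Cn2cc(-c3ccc(Br)cc3)nn2)C(OCc2ccccc2)=C1OCc1ccccc1` gives only a limit of the assay, > 100000 nM. Among the measured compounds shown here, the one measured change, an at least 3.5-fold lower number from compound 1 to compound 3 (0.55 log units; beyond the scatter), sits on the core of compound 1 rather than that of compound 2, and the limit of > 100000 nM in this assay, at which 1 of the 3 values shown sits, makes its size a lower bound only. Compound 4 `O=C1O[C@H]([C@@H](O)Cn2ccnn2)C(OCc2ccccc2)=C1OCc1ccccc1` differs from compound 2 by hydrogen in place of tert-butyl on an aromatic carbon. For the measured compounds named here, no measured step covers this change, so the expectation rests on compound 2 alone. A modest weakening of compound 4 is expected, a 3.4-fold higher number from compound 2 to compound 4 (0.53 log units; beyond the scatter). Compound 4 is therefore estimated at 2500 nM, within 700 nM to 9000 nM.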

Compound 4, half-maximal inhibitory concentration: > 100000 nM
Compound 4 was reported as a limit; the forecaster's own chance of this, stated with the estimate: 5%; middle value at least 40-fold (1.60 log units) away from the limit.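

Hydrogen in place of tert-butyl on the aromatic carbon brings an at least 130-fold higher number from compound 2 to compound 4 (2.13 log units; beyond the scatter) in this assay, so on the core of compound 2 the activity depends on what this carbon carries, which the earlier step, on the core of compound 1, could not show. The value of compound 4 is a limit, so this large step gives a lower bound only: the limit of > 100000 nM in this assay, at which 2 of the 4 values shown sit.

As far as these compounds go, it remains open whether a methyl, an isopropyl or an aminomethyl group on this carbon would keep the activity of compound 2. From the compounds shown here alone, it also remains open whether the 3-hydroxyphenyl group would do so on that core.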